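Replacing the 3,4,5-trimethoxyphenyl group of compound 1

The source may report more compounds than this note shows. Statements on the series, on what has been measured and on what is new or still open speak of the compounds shown alone.

Compound 1 (`COc1cc(CN(C(=O)CSc2nc3ccccc3s2)c2cc(OC)c(OC)c(OC)c2)cc(OC)c1OC`): 45700 nM
Compound 2 (`COc1ccc(CN(C(=O)CSc2nc3c(C)cccc3s2)c2cc(OC)c(OC)c(OC)c2)cc1O`): 493 nM

Both numbers come from a functional assay on MGC-803 cells (Homo sapiens) for antiproliferative activity, read by MTT assay, with a stated time of 48 h; a lower number here means a stronger inhibitor, a higher number a weaker inhibitor. Compound 1 (45700 nM) holds the higher of the two numbers, which makes it the weaker inhibitor. The gap from compound 1 to compound 2 lies well beyond the usual scatter. Within the data shown here, no two measured compounds differ in just one place, so no single structural change has a measured size yet.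

Compound 3 (`COc1ccc(CN(C(=O)CSc2nc3ccccc3s2)c2cc(OC)c(OC)c(OC)c2)cc1C(F)(F)F`) has not been measured. It carries 4-methoxy-3-(trifluoromethyl)phenyl in place of 3,4,5-trimethoxyphenyl on a saturated chain carbon bound to an amide-type nitrogen. The rest of the structure of compound 1 stays the same.

Compound 1 sits high on the scale, and compound 2 (493 nM) shows that far lower numbers occur among these compounds. A moderate fall therefore seems more likely than a rise, though the evidence is thin. In this assay the expected change is estimated as a 7.6-fold lower number from compound 1 to compound 3 (0.88 log units; beyond the scatter). For compound 3 the expected value is 6000 nM, with an estimated range from 800 nM to 40000 nM.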

Compound 3, half-maximal inhibitory concentration: 25200 nM
Beside the measured number, compound 3's estimate is 4.2-fold (0.62 log units) below it; the range from low to high includes it.
By their numbers in this assay, from the lowest: compound 2; then compounds 3 and 1 (each within the scatter of the next).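

In this assay, among these compounds, putting 4-methoxy-3-(trifluoromethyl)phenyl in place of 3,4,5-trimethoxyphenyl on a saturated chain carbon bound to an amide-type nitrogen gives a 1.8-fold lower number from compound 1 to compound 3 (0.26 log units; within the scatter), the first single-place change in this set with a measured size. The two groups have the same count of 12 heavy atoms, but the hydrogen-bond acceptors go from 3 to 1 and two of the three methoxy groups are gone, so for this pair, such a large rewrite of the group leaves the number indistinguishable from that of compound 1. No measured property of either group is available to explain this result.

Compound 2 differs from compound 1 in more than one place, so the shown compounds cannot say how much of its much lower number belongs to its hydroxyl group and how much to the methyl group on its core. Also open, as far as these compounds go, is how a phenyl ring carrying an amine or a carboxylic acid would behave at this same place on the chain.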